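A Methyl Added to the Ethyl Chain of Compound 1

The compounds below may be only part of what the source reports. "The series", "measured", "known", "first", "only" and "open" are said of these compounds alone.

The measured compounds and their values:
Compound 1 `CCc1ccc(C(=O)/C=C/C(=O)O)cc1` gives 21000 nM in a functional assay on LS174T cells (Homo sapiens) for inhibition, read by MTT assay, with a stated time of 72 h; on this read-out lower numbers stand for stronger inhibition and higher numbers for weaker inhibition.
Compound 2 `Cc1ccc(C(=O)/C=C/C(=O)O)cc1C` gives 12100 nM in this assay.
Compound 3 `O=C(O)/C=C/C(=O)C1CCc2ccccc2C1` gives 17600 nM in this assay.

Among these three numbers compound 1 carries the highest, but its distance to compound 3 and to compound 2 both lie within the usual scatter of this assay, so the three compounds cannot be set apart from one another on the numbers shown. Compound 1 is thus a fair point of departure for a small change, with the understanding that none of its neighbours gives a lead on which way that change might pull.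

The change to compound 4 `CC(C)c1ccc(C(=O)/C=C/C(=O)O)cc1` is a single added carbon: methyl in place of hydrogen on a saturated chain carbon bound to an aromatic carbon and a saturated chain carbon. Cut one bond further out, the same difference reads ethyl to isopropyl.

Among the compounds with values here, no measured pair in this set shows what such an addition does, and the three measured compounds are indistinguishable from each other, so there is no basis for expecting a move beyond the scatter. The estimated step in this assay from compound 1 to compound 4 is small, a 1.2-fold lower number from compound 1 to compound 4 (0.07 log units; within the scatter), and may lie in either direction. Compound 4 is therefore expected to give about 18000 nM, between 7000 nM and 45000 nM.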

Compound 4, half-maximal inhibitory concentration: 25700 nM
Beside the measured number, compound 4's estimate is 1.4-fold (0.15 log units) below it, within the range that was stated.
By their numbers in this assay, from the lowest: compounds 2, 3, 1 and 4 (each within the scatter of the next, the first and the last beyond it).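

In this assay, the ethyl to isopropyl change gives a 1.2-fold higher number from compound 1 to compound 4 (0.09 log units; within the scatter), so this single added carbon, methyl in place of hydrogen on a saturated chain carbon bound to an aromatic carbon and a saturated chain carbon, does not set compound 4 apart from compound 1 on this read-out. Within the data shown here, this is the first pair in the set that differs in one place, so it gives the first direct reading at this position, where the earlier compounds offered none. No measurement at hand accounts for this result, and the data give no explanation of why the two compounds cannot be told apart.

One step within the scatter does not show how far this position stays silent: a tert-butyl group, a longer chain, or a hydroxyl or amine on the same carbon might leave the number where it is or carry it beyond the scatter. It also leaves open whether the same added methyl would read the same way on another core, since this pair gives a single reading on the core of compound 1.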